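Amide chain variation in a dimethoxy acid series

The compounds below may be only part of what the source reports. "The series", "measured", "known", "first", "only" and "open" are said of these compounds alone.

Measured compounds and values in a functional assay on the whole organism (strain Swiss albino) for inhibition, with Mus musculus as the target, in the writhing test, with stated times of 60 min and 15 min, at a dose of 100 mg/kg by the oral route; on this read-out higher numbers stand for more inhibition at the one dose given (going by the name of the read-out) and lower numbers for less inhibition:
compound 1, `COc1cc2c(cc1OC)C(CC(=O)O)CC2`: 44%
compound 2, `CCCNC(=O)CC1CCc2cc(OC)c(OC)cc21`: 26.9%
compound 3, `CCCCCNC(=O)CC1CCc2cc(OC)c(OC)cc21`: 71.7%

Compound 3 gives the highest number of the three, with compound 1 as the nearest and compound 2 as the furthest; both gaps lie beyond the scatter. The two amide steps from the acid run in opposite directions: a number 17.1 percentage points lower from compound 1 to compound 2 (beyond the scatter), whereas a number 27.7 percentage points higher from compound 1 to compound 3 (beyond the scatter). Within the amides, a number 44.8 percentage points higher from compound 2 to compound 3 (beyond the scatter).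

Compound 4, `COc1cc2c(cc1OC)C(CC(=O)NCc1ccccc1)CC2`, is not yet measured in this assay. It differs from compound 3 as follows: phenyl in place of butyl on a saturated chain carbon bound to an amide-type nitrogen. Cut one bond further out the change reads pentylamino to benzylamino, so the chain keeps about the same length while an aromatic ring replaces the open end.

The measured steps bear on this only indirectly: they show that the size of the group on the amide nitrogen moves the read-out strongly, with the longer pentylamino well above the propylamino and the acid, but no aromatic group on that nitrogen has been tried. Going by the values given here, with the chain length roughly preserved, a small step is expected, if any, most likely downward, since there is no precedent for the ring: a number 11.7 percentage points lower from compound 3 to compound 4 (beyond the scatter) is the expected step. For compound 4 the estimate in this assay is 60%, with a range from 35% to 80%.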

Compound 4, a percentage reported as inhibition, in the whole organism at one dose (the size of the read-out at that dose, not a potency): 48.1%
For compound 4 the middle estimate is 11.9 percentage points above the measured one, within the range that was stated.
By their numbers in this assay, from the lowest: compound 2; then compounds 1 and 4 (each within the scatter of the next); then compound 3.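

In this assay, going by these compounds alone, the first aromatic group on the amide nitrogen falls inside the span of the two open-chain amides: there is a number 23.6 percentage points lower from compound 3 to compound 4 (beyond the scatter) when phenyl stands in place of butyl on the saturated chain carbon bound to the amide-type nitrogen, but a number 21.2 percentage points higher from compound 2 to compound 4 (beyond the scatter) when phenyl stands in place of ethyl at that same carbon. Thus the high read-out of the pentylamino amide does not carry over to the benzylamino amide, although the benzylamino amide stays well clear of the propylamino amide, so the nature of the group at this carbon matters and not only the presence of an amide. Measured against the acid, there is a number 4.1 percentage points higher from compound 1 to compound 4 (within the scatter), which makes benzylamino the only one of the three amine groups in place of hydroxy whose step lies within the scatter, and no data at hand account for any of these steps.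

On these data alone, whether a longer chain such as hexylamino would extend the gain seen from propylamino to pentylamino remains open. Also open, as far as these compounds go, is how phenethylamino, or a benzylamino group carrying a methoxy or chloro substituent on its phenyl ring, would read out at this dose.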